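Bromo for Chloro on a Weakly Inhibiting Compound

The source may hold more compounds than are shown below. What is called first, only, known or untested is meant among the compounds shown, and "the series" means these compounds.

Compound 1 `Nc1nc2cc(Cl)c(Cl)cc2n1Cc1cccc(C(F)(F)F)c1` gives 45000 nM here
Compound 2 `Clc1cc2nc(Cl)n(Cc3ccccc3Cl)c2cc1Cl` gives 156000 nM here
Compound 3 `Clc1ccc(Cn2c(Br)nc3cc(Cl)c(Cl)cc32)cc1Cl` gives > 100000 nM here

All three compounds were tested in a functional assay on KB cells (Homo sapiens) for inhibition (on this read-out higher numbers stand for weaker inhibition and lower numbers for stronger inhibition), and only two of them returned actual numbers. Compound 2 at 156000 nM holds the higher of those two numbers. Compound 1 at 45000 nM lies lower, and the gap goes beyond the usual scatter. The reading for compound 3 (> 100000 nM) is a limit and not a number.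

The next compound to be measured is compound 4 `Clc1cc2nc(Br)n(Cc3ccccc3Cl)c2cc1Cl` which differs from compound 2 in one place. The change is bromo in place of chloro on an aromatic carbon with bromo in place of chloro on an aromatic carbon between two ring nitrogen atoms. For the measured compounds named here, no measured pair of compounds shows this swap on its own, so the expectation rests on little. Compound 3 also carries bromo on that carbon, but its reading (> 100000 nM) is a limit. In this assay the expected change is a 1.3-fold lower number from compound 2 to compound 4 (0.11 log units; within the scatter) which would stay within the scatter. Compound 4 is estimated at 120000 nM with an expected range of 50000 nM to 280000 nM for its measurement.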

Compound 4, half-maximal inhibitory concentration: 78000 nM
Beside the measured number, compound 4's estimate is 1.5-fold (0.19 log units) above it, and the stated range covers the measured number.
By their numbers in this assay, from the lowest: compounds 1, 4 and 2 (each within the scatter of the next, the first and the last beyond it).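

In this assay, for the compounds shown here, bromo in place of chloro gives a 2.0-fold lower number from compound 2 to compound 4 (0.30 log units; within the scatter) and so provides the first reading of this swap on its own, on an aromatic carbon between two ring nitrogen atoms. Compound 4 thereby gives an actual number for a bromo compound at this position, and on this single pair the two halogens cannot be told apart. Compound 3 also carries bromo on that carbon, but its reading is a limit and not a number: the limit of > 100000 nM in this assay, at which 1 of the 4 values shown sits.

The compounds shown leave open whether a methyl group, a nitrile or a methoxy group on this carbon would read any differently from the chloro and bromo of compound 2 and compound 4 if the rest of the structure stayed the same. They also leave open whether the swap would give a similar step with another group in place of the one on the neighbouring ring atom, since this single pair is the only measured case and it cannot tell what lies behind the step.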